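Trimethoxyphenyl on the five-membered ring of compound 2

The source may report more compounds than this note shows. Statements on the series, on what has been measured and on what is new or still open speak of the compounds shown alone.

Compound 2 `COc1ccc(-c2cn(-c3cccc(C(=O)/C=C/c4cc(OC)c(OC)c(OC)c4)c3)c(=O)[nH]2)cc1` gives 6220 nM in a functional assay on PC-3 cells (Homo sapiens) for inhibition (on this read-out lower numbers stand for stronger inhibition of growth and higher numbers for weaker inhibition of growth), the highest of the three numbers in the set. Compound 3 `COc1ccc(-c2cn(-c3cccc(C(=O)/C=C/c4ccc(O)c(OC)c4)c3)c(=O)[nH]2)cc1` gives 3050 nM and compound 1 `COc1cc(/C=C/C(=O)c2cccc(-n3cc(-c4ccccc4)[nH]c3=O)c2)ccc1O` gives 2520 nM. The step of a 2.0-fold lower number from compound 2 to compound 3 (0.31 log units; beyond the scatter) changes the aryl on the chain, not the aryl on the five-membered ring, so it does not bear on the change considered here. The step of a 1.2-fold higher number from compound 1 to compound 3 (0.08 log units; within the scatter) is the only one at the relevant site and lies within the scatter.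

Compound 4 `COc1cc(/C=C/C(=O)c2cccc(-n3cc(-c4cc(OC)c(OC)c(OC)c4)[nH]c3=O)c2)cc(OC)c1OC` differs from compound 2 by 3,4,5-trimethoxyphenyl in place of 4-methoxyphenyl on an aromatic carbon. Within the data shown here, since the one measured change at this site, a 1.2-fold higher number from compound 1 to compound 3 (0.08 log units; within the scatter), moved the number by no more than the scatter, no step beyond the scatter is expected in this assay for compound 4 either; compound 2 already being the highest number, a slightly higher number is expected if anything. Compound 4 is therefore estimated at 7000 nM, between 3500 nM and 15000 nM, an expected step of a 1.1-fold higher number from compound 2 to compound 4 (0.05 log units; within the scatter).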

Compound 4, concentration for 50% growth inhibition: 2630 nM
For compound 4 the middle estimate is 2.7-fold (0.43 log units) above the measured one; measured number outside the range, below it.
By their numbers in this assay, from the lowest: compounds 1, 4 and 3 (each within the scatter of the next); then compound 2.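

In this assay, the aryl group on the five-membered ring turns out to be able to move the number: 3,4,5-trimethoxyphenyl in place of 4-methoxyphenyl gives a 2.4-fold lower number from compound 2 to compound 4 (0.37 log units; beyond the scatter), a modest gain with 3,4,5-trimethoxyphenyl also on the chain. The earlier step at this site, a 1.2-fold higher number from compound 1 to compound 3 (0.08 log units; within the scatter), was a different change, methoxy in place of hydrogen with 4-hydroxy-3-methoxyphenyl on the chain, so the site cannot be treated as insensitive to every change. No measurement on hand accounts for the gain.

As far as these compounds go, it remains open whether the same exchange on the five-membered ring would give a similar step with 4-hydroxy-3-methoxyphenyl on the chain. Also open, from the compounds shown here alone, is how a phenyl carrying an amine or a carboxylic acid would behave on this aromatic carbon.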